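The compounds below may be only part of what the source reports. "The series", "measured", "known", "first", "only" and "open" are said of these compounds alone.

Among the compounds with values here, in an ADME assay on microsomes from liver (Mus musculus) for metabolic stability, read by LC-MS, with a stated time of 10 min, tested at 0.5 uM (a higher number here means that more of the compound is left, a lower number that less of the compound is left), compound 2 (`c1ccc2c(c1)CN[C@@H](CN(CCC1CCNCC1)[C@H]1CCCc3cccnc31)C2`) gives 32%, the middle of the three numbers so far, with compound 1 (`c1ccc2c(c1)CN[C@@H](CN(CC1CCNCC1)[C@H]1CCCc3cccnc31)C2`) at 13% and compound 3 (`c1cnc2c(c1)CN[C@H](CN(CCCN1CCNCC1)[C@H]1CCCc3cccnc31)C2`) at 63%. The next change leads to compound 4 (`NC(=O)N1CCN(CCCN(C[C@H]2Cc3ccccc3CN2)[C@H]2CCCc3cccnc32)CC1`), with (4-carbamoylpiperazin-1-yl)methyl in place of piperidin-4-yl on a saturated chain carbon, two bonds along the chain from an amine nitrogen. Within the data shown here, the only measured step at this place is a number 19 percentage points higher from compound 1 to compound 2 (beyond the scatter), which is modest and beyond the scatter. It covers (piperidin-4-yl)methyl in place of piperidin-4-yl, so it speaks to only part of the new group. Among the measured compounds shown here, compound 3, whose side chain also carries a six-membered non-aromatic ring with 2 hetero atoms, reaches 63%, but its core differs and no measured step ties it to compound 4. An upward move beyond the scatter is therefore expected, with an estimated size of a number 23 percentage points higher from compound 2 to compound 4 (beyond the scatter). The estimate for compound 4 is 55%, with an expected range from 35% to 75%.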

Compound 4, percent of the compound remaining: 42%
Compound 4: middle estimate off by 13 percentage points, on the high side; the measured number falls inside the stated range.
By their numbers in this assay, from the lowest: compound 1; then compounds 2 and 4 (each within the scatter of the next); then compound 3.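

In this assay, (4-carbamoylpiperazin-1-yl)methyl in place of piperidin-4-yl on a saturated chain carbon, two bonds along the chain from an amine nitrogen, gives a number 10 percentage points higher from compound 2 to compound 4 (within the scatter). At this position, the larger carbamoyl-bearing group therefore cannot be separated from the smaller group it replaces. The longer comparison, with the whole side-chain group exchanged on a saturated chain carbon bound to an amine nitrogen, gives a number 29 percentage points higher from compound 1 to compound 4 (beyond the scatter), and nothing measured bears on the reason for either step.

As far as these compounds go, it remains open whether the piperazine ring or the carbamoyl accounts for the larger step. A plain piperazin-1-yl group on the same chain, or an acetyl group in place of the carbamoyl, would address that on the shared core.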